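Side-chain variation at the ring nitrogen of compound 1

A few compounds are considered here, and "the series" means these few. Any claim that something is new, unique, unknown or untested is made for them only; others in the source may bear on it.

compound 1 `NNc1nonc1/C(=N/O)Nc1ccc(F)c(Br)c1`: 556 nM
compound 2 `NS(=O)(=O)NNc1nonc1/C(=N/O)Nc1ccc(F)c(Br)c1`: 101 nM
compound 3 `CCNS(=O)(=O)CCNc1nonc1/C(=N/O)Nc1ccc(F)c(Br)c1`: 41 nM

In an assay on HeLa cells for inhibition of Indoleamine 2,3-dioxygenase 1 (Homo sapiens), read by spectrophotometry, with a stated time of 24 h (on this read-out higher numbers stand for an effect only at larger amounts of compound and lower numbers for an effect already at smaller amounts), compound 1 stands highest of the three numbers; the nearest is a 5.5-fold lower number from compound 1 to compound 2 (0.74 log units; beyond the scatter) and the furthest is a 14-fold lower number from compound 1 to compound 3 (1.13 log units; beyond the scatter). Compound 4, `NS(=O)(=O)CCONc1nonc1/C(=N/O)Nc1ccc(F)c(Br)c1`, differs from compound 1 by 2-sulfamoylethoxy in place of amino on a nitrogen on an aromatic ring. Among the measured compounds shown here, two measured steps bear on this change, a 5.5-fold lower number from compound 1 to compound 2 (0.74 log units; beyond the scatter) and a 14-fold lower number from compound 1 to compound 3 (1.13 log units; beyond the scatter), each of which put a sulfamoyl-bearing group at or close to this nitrogen and each lowered the number beyond the scatter; in addition, a 2.5-fold lower number from compound 2 to compound 3 (0.39 log units; beyond the scatter) shows the longer chain giving the lower number. A step of the same kind is therefore expected in this assay, a 7.0-fold lower number from compound 1 to compound 4 (0.84 log units; beyond the scatter). Compound 4 is estimated at 80 nM, with a range from 30 nM to 250 nM.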

Compound 4, half-maximal effective concentration: 27 nM
Beside the measured number, compound 4's estimate is 3.0-fold (0.47 log units) above it; measured number below the stated range.
By their numbers in this assay, from the lowest: compounds 4 and 3 (each within the scatter of the next); then compound 2; then compound 1.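

In this assay 2-sulfamoylethoxy on this nitrogen gives a large step, a 21-fold lower number from compound 1 to compound 4 (1.31 log units; beyond the scatter), and it also separates from the sulfamoylamino group, a 3.7-fold lower number from compound 2 to compound 4 (0.57 log units; beyond the scatter). Against 2-(ethylsulfamoyl)ethyl there is no separation, a 1.5-fold lower number from compound 3 to compound 4 (0.18 log units; within the scatter), so these two side chains cannot be told apart here. No measurement at hand accounts for these steps. Still open, as far as these compounds go, is whether a 2-sulfamoylethyl chain without the oxygen would match compound 4. Also open, from the compounds shown here alone, is whether a carboxylic acid in place of the sulfamoyl group would keep the number this low.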